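The source may hold more compounds than are shown below. What is called first, only, known or untested is meant among the compounds shown, and "the series" means these compounds.

Compound 1, `CCC(C)OC(=O)c1cc(CN2CCCC2)c(O)c(CN2CCCC2)c1`, in a functional assay for inhibition, with Cavia porcellus as the target; a lower number here means that less compound is needed, a higher number that more compound is needed for the effect: 6.7 ug/mL
Compound 2, `CCCCOC(=O)CCc1cc(CN2CCCC2)c(O)c(CN2CCCC2)c1`, in this assay: 2.5 ug/mL
Compound 3, `O=C(Nc1ccccc1)c1cc(CN2CCCC2)c(O)c(CN2CCCC2)c1`, in this assay: 11 ug/mL

Compound 2 holds the lowest of the three numbers in this assay. The step of a 2.7-fold lower number from compound 1 to compound 2 (0.43 log units; beyond the scatter) and the step of a 4.4-fold higher number from compound 2 to compound 3 (0.64 log units; beyond the scatter) both lie beyond the scatter and set compound 2 apart from the other two. Compound 1 and compound 3 are within the scatter of each other: a 1.6-fold higher number from compound 1 to compound 3 (0.22 log units; within the scatter).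

Compound 4, `O=C(O)CCc1cc(CN2CCCC2)c(O)c(CN2CCCC2)c1`, is not yet measured. Against compound 2 the change is hydrogen in place of butyl on an oxygen next to a carbonyl group; cut one bond further out it reads butoxycarbonyl to carboxy. Within the data shown here, no measured step removes the butyl from this oxygen, so no direct precedent exists. The steps that alter the same part of the shared core are a 2.7-fold lower number from compound 1 to compound 2 (0.43 log units; beyond the scatter) and a 4.4-fold higher number from compound 2 to compound 3 (0.64 log units; beyond the scatter), both modest in size. A step of similar, modest size is therefore expected in this assay, more likely towards a higher number, since compound 2 already stands at 2.5 ug/mL, the lowest point of the set, and both measured departures from it raised the number. Compound 4 is expected to give about 8 ug/mL, with a range of 2.5 ug/mL to 25 ug/mL. The expected step from compound 2 is a 3.2-fold higher number from compound 2 to compound 4 (0.51 log units; beyond the scatter).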

Compound 4, concentration for half-maximal effect: > 1000 ug/mL
Compound 4: a limit, no number; the forecaster's own chance of this, stated with the estimate: 10%; at least 120-fold (2.09 log units) between middle value and limit.
By their numbers in this assay, from the lowest: compound 2; then compounds 1 and 3 (each within the scatter of the next). At a limit, above all of these: compound 4.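

Compound 4 gives only a limit in this assay, not a number: the limit of > 1000 ug/mL in this assay, at which 1 of the 4 values shown sits.

The earlier compounds shown here varied this substituent only among capped carbonyl groups (sec-butoxycarbonyl, 2-(butoxycarbonyl)ethyl and phenylcarbamoyl), and their steps were modest or within the scatter. Removing the butyl from the oxygen next to the carbonyl group is a far larger change in this assay than any of those, with an at least 400-fold higher number from compound 2 to compound 4 (2.60 log units; beyond the scatter) as the one-place comparison, and the free carboxy chain also stands well apart from the other two compounds, with an at least 140-fold higher number from compound 1 to compound 4 (2.17 log units; beyond the scatter) and an at least 90-fold higher number from compound 3 to compound 4 (1.95 log units; beyond the scatter). Among the compounds shown, the carbonyl group on its own is therefore not enough for a measurable number, and all three compounds with a capped carbonyl give one, while the hydrogen in place of butyl does not.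

On these data alone, how much of the butyl is needed remains open, and a methyl ester or ethyl ester on the same chain would place the threshold between butyl and hydrogen. As far as these compounds go, a primary amide on this chain would show whether a carbonyl capped by an amine nitrogen rather than an alkoxy group keeps the number, and the true size of the loss stays unknown while compound 4 stands at a limit.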